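The source may report more compounds than this note shows. Statements on the series, on what has been measured and on what is new or still open speak of the compounds shown alone.

In a physicochemical assay, read by LC-MS, with a stated time of 24 h, at pH 7.4, tested at 2 uM (on this read-out higher numbers stand for a more stable compound and lower numbers for a less stable compound), compound 1 (`O=C(O)c1ccc(NCc2c(-c3c(Cl)cccc3C(F)(F)F)noc2-c2ccco2)cc1`) shows 100% remaining and compound 2 (`O=C(O)c1ccc(NC(=O)c2c(-c3c(Cl)cccc3C(F)(F)F)noc2-c2ccccc2)cc1`) shows 95.4% remaining. Within the data shown here, these two numbers lie within the usual scatter of each other, so compound 1 stands level with compound 2 on the numbers so far. Compound 3 (`O=C(O)c1ccc(NCc2c(-c3c(Cl)cccc3C(F)(F)F)noc2-c2cc[nH]c2)cc1`) keeps the core of compound 1 but has 1H-pyrrol-3-yl in place of furan-2-yl on an aromatic carbon. Among the measured compounds shown here, no measured pair isolates this change, so the data offer no direct guide to its effect. The expectation rests only on compound 1 at 100% and compound 2 at 95.4% and is for no step beyond the scatter in this assay, with a slight downward drift at most. The estimated change is (a number 5 percentage points lower from compound 1 to compound 3 (within the scatter)). Compound 3 is expected to show 95% remaining, with an estimated range of 82% to 100% in this read-out.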

Compound 3, percent of the compound remaining: 95.3%
For compound 3 the middle estimate is 0.3 percentage points below the measured one, within the range that was stated.
By their numbers in this assay, from the lowest: compounds 3, 2 and 1 (each within the scatter of the next).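

In this assay, among these compounds, placing 1H-pyrrol-3-yl in place of furan-2-yl on the aromatic carbon next to the ring oxygen gives a number 4.7 percentage points lower from compound 1 to compound 3 (within the scatter) and is the first single-place comparison at this position. With the rest of the core of compound 1 held constant, exchanging the hydrogen-bond acceptor of furan-2-yl for the hydrogen-bond donor of 1H-pyrrol-3-yl therefore produces no step beyond the scatter. Nothing available accounts for this result or links it to a property of either ring.

Still open, on these data alone, is how a pyridine ring, an amine such as morpholine, or a longer alkyl chain would read at this position. As far as these compounds go, it also remains open whether any group here would give a step beyond the scatter in this assay.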